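The source may hold more compounds than are shown below. What is called first, only, known or untested is meant among the compounds shown, and "the series" means these compounds.

Compound 1 `N#Cc1ccc(Nc2nc(Oc3ccnc4ccccc34)nc(N3CCN(c4ccc(F)cc4)CC3)n2)cc1C(F)(F)F`: in a functional assay on DU-145 cells (Homo sapiens) for cytotoxicity, read by sulforhodamine B assay, with a stated time of 48 h (a lower number here means a stronger inhibitor of growth, a higher number a weaker inhibitor of growth), compound 1 reaches only the assay's limit, > 100000 nM.
Compound 2 `CC1CC(C)CN(c2nc(Nc3ccc(C#N)c(C(F)(F)F)c3)nc(Oc3ccnc4ccccc34)n2)C1`: compound 2 gives 68000 nM.
Compound 3 `N#Cc1ccc(Nc2nc(Oc3ccnc4ccccc34)nc(N3CCN(c4cccc(C(F)(F)F)c4)CC3)n2)cc1C(F)(F)F`: compound 3 gives 74100 nM.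

Compound 3 and compound 2 lie within the usual scatter of each other, so neither can be called the weaker of the two, while compound 1 is known only as a limit. Compound 4 `CC(C)N1CCN(c2nc(Nc3ccc(C#N)c(C(F)(F)F)c3)nc(Oc3ccnc4ccccc34)n2)CC1` differs from compound 3 by isopropyl in place of 3-(trifluoromethyl)phenyl on an amine nitrogen in a ring. Within the data shown here, the one measured step at this position is an at least 1.3-fold lower number from compound 1 to compound 3 (0.13 log units; that floor lies within the scatter), which exchanged one aryl group for another and stayed within the scatter, with the limit of > 100000 nM in this assay, at which 1 of the 3 values shown sits, capping its size. Among the measured compounds shown here, no measured step replaces an aryl group by an alkyl group, but compound 2, whose ring carries no aryl group at all, sits close to compound 3. A step in this assay no larger than the scatter is therefore expected. Compound 4 is estimated at 70000 nM, with a range from 30000 nM to 160000 nM, so a 1.1-fold lower number from compound 3 to compound 4 (0.02 log units; within the scatter) is the expected step.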

Compound 4, concentration for total growth inhibition: > 100000 nM
Compound 4: no number, only a limit; the forecaster's own chance of this, stated with the estimate: 35%; middle value at least 1.4-fold (0.15 log units) from the limit.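

With isopropyl in place of 3-(trifluoromethyl)phenyl on the ring amine nitrogen, the result is an at least 1.3-fold higher number from compound 3 to compound 4 (0.13 log units; that floor lies within the scatter). Changing the whole group on the aromatic carbon, 4-isopropylpiperazin-1-yl in place of 3,5-dimethylpiperidin-1-yl, gives an at least 1.4-fold higher number from compound 2 to compound 4 (0.16 log units; that floor lies within the scatter). An alkyl group on this nitrogen thus brings no visible gain over an aryl group, the step from compound 1 cannot be read, and values now gather at the ceiling: the limit of > 100000 nM in this assay, at which 2 of the 4 values shown sit.

As far as these compounds go, what a bare amine hydrogen or a hydroxyethyl chain on this nitrogen would give stays open. From the compounds shown here alone, the true size of the change also stays open, since compound 4 is known only as a limit.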